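Notes on compound 2 and its propyl analogue

The compounds below may be only part of what the source reports. "The series", "measured", "known", "first", "only" and "open" are said of these compounds alone.

Measured so far:
compound 1, `CCCc1nnsc1CO/N=C/c1c(C)nn(C)c1Oc1ccccc1Cl`: > 50000 nM
compound 2, `CCc1nnsc1CO/N=C/c1c(C)nn(C)c1Cl`: > 50000 nM

In a functional assay on PANC-1 cells (Homo sapiens) for inhibition, read by MTT assay, with a stated time of 48 h (on this read-out lower numbers stand for stronger inhibition and higher numbers for weaker inhibition), compound 1 gives > 50000 nM, which is a limit of the assay and not a number. In this assay compound 2 gives > 50000 nM, likewise a limit. Compound 2 stands at the limit of > 50000 nM in this assay, at which 2 of the 2 values shown sit. Going by the values given here, no measured step connects the two compounds.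

Compound 3, `CCCc1nnsc1CO/N=C/c1c(C)nn(C)c1Cl`, differs from compound 2 by methyl in place of hydrogen on a saturated chain carbon, two bonds along the chain from an aromatic carbon. Among the compounds with values here, with no measured step to draw on, the expected change is none beyond the scatter, a step that the limit leaves unreadable from compound 2 to compound 3. Compound 3 is therefore expected to give 60000 nM, within 25000 nM to 150000 nM, most likely again reported only as a limit.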

Compound 3, half-maximal inhibitory concentration: > 50000 nM
Compound 3 ended at the assay's limit; the forecaster's own chance of this, stated with the estimate: 80%; the middle value lies beyond the limit too.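

No step can be read from compound 2 or compound 1 to compound 3, whose result in this assay is again only a limit: the limit of > 50000 nM in this assay, at which 3 of the 3 values shown sit. The compounds shown leave open whether ethyl to propyl or chloro to 2-chlorophenoxy changes inhibition at all.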